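The compounds below may be only part of what the source reports. "The series", "measured", "known", "first", "only" and "open" are said of these compounds alone.

In an assay on cells for inhibition of Pendrin (Mus musculus), read by fluorescence, with a stated time of 10 min (on this read-out lower numbers stand for stronger inhibition and higher numbers for weaker inhibition), the measured compounds are:
- compound 1 `Cn1nc(COc2cccc(F)c2)c2c1CCN(C(=O)Nc1ccc(Cl)cc1)C2` gives 6600 nM
- compound 2 `Cn1nc(COc2ccc(F)c(F)c2)c2c1CCN(C(=O)Nc1ccc(Cl)cc1)C2` gives 4600 nM
- compound 3 `Cn1nc(COc2cc(F)cc(F)c2)c2c1CCN(C(=O)Nc1ccc(Cl)cc1)C2` gives 3100 nM

For the measured compounds named here, compound 3 has the lowest number of the three; its gap to compound 2 sits within the scatter, while a 2.1-fold lower number from compound 1 to compound 3 (0.33 log units; beyond the scatter) goes beyond it, so only that comparison counts as a real step.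

Compound 4 `CCOC(=O)c1nn(C)c2c1CN(C(=O)Nc1ccc(Cl)cc1)CC2` differs from compound 3 in one place: ethoxycarbonyl in place of (3,5-difluorophenoxy)methyl on an aromatic carbon. Going by the values given here, no measured step bears on this change. The known steps only swap hydrogen for fluoro on the aromatic ring that now leaves, and they were small: a 1.4-fold lower number from compound 1 to compound 2 (0.16 log units; within the scatter), a 1.5-fold lower number from compound 2 to compound 3 (0.17 log units; within the scatter) and a 2.1-fold lower number from compound 1 to compound 3 (0.33 log units; beyond the scatter). From the compounds shown here alone, removing that whole ring is a far larger change, and its direction in this assay is unknown; a weakening beyond the scatter seems the more likely outcome, so compound 4 is expected to show a 3.9-fold higher number from compound 3 to compound 4 (0.59 log units; beyond the scatter) and is estimated at 12000 nM, within a range of 3000 nM to 40000 nM.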

Compound 4, half-maximal inhibitory concentration: > 10000 nM
Compound 4 was reported as a limit; the forecaster's own chance of this, stated with the estimate: 30%; the middle value does not contradict the limit.
By their numbers in this assay, from the lowest: compounds 3, 2 and 1 (each within the scatter of the next, the first and the last beyond it). At a limit, above all of these: compound 4.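

Replacing the whole (3,5-difluorophenoxy)methyl group with ethoxycarbonyl on this aromatic carbon gives a clearer loss of inhibition in this assay than any single fluoro swap could show: an at least 3.2-fold higher number from compound 3 to compound 4 (0.50 log units; beyond the scatter) and an at least 2.1-fold higher number from compound 2 to compound 4 (0.33 log units; beyond the scatter). The comparison with the monofluoro compound is less firm, with an at least 1.5-fold higher number from compound 1 to compound 4 (0.18 log units; that floor lies within the scatter). The full size of these steps cannot be read, as compound 4 stands at a limit: the limit of > 10000 nM in this assay, at which 1 of the 4 values shown sits.

Still open, from the compounds shown here alone, is whether an aminomethyl or carboxylic acid group on this carbon would read differently from ethoxycarbonyl. A simple benzyloxymethyl group would also test how far the fluoro atoms matter once the aromatic ring stays in place.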